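This account rests on a few compounds, and the source may have more. Where it says the series, first, only, none or still open, it means among the compounds named here.

Measured compounds:
Compound 1 `COc1cc(OC)c(-c2coc3cc(OCC=C(C)C)ccc3c2=O)cc1OC` gives 1090 nM in a functional assay on B16 cells (Mus musculus) for antiproliferative activity, read by MTT assay, with a stated time of 24 h; on this read-out higher numbers stand for weaker inhibition and lower numbers for stronger inhibition.
Compound 2 `COc1cccc(C(=O)Oc2ccc3c(=O)c(-c4cc(OC)c(OC)cc4OC)coc3c2)c1` reports only the assay limit of > 10000 nM in this assay.
Compound 3 `COc1cc(OC)c(-c2coc3cc(OCc4ccc(Cl)cc4)ccc3c2=O)cc1OC` gives 2400 nM in this assay.

For the measured compounds named here, compound 2 is therefore the one member of the set with no number, only a limit (the limit of > 10000 nM in this assay, at which 1 of the 3 values shown sits), and it sits at the weak end of what has been measured. Against the prenyl ether compound 1 the step is an at least 9.1-fold higher number from compound 1 to compound 2 (0.96 log units; beyond the scatter), and against the 4-chlorobenzyl ether compound 3 it is an at least 4.1-fold lower number from compound 2 to compound 3 (0.61 log units; beyond the scatter); the two benzyl-type ethers are separated by a 2.2-fold higher number from compound 1 to compound 3 (0.34 log units; beyond the scatter).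

Compound 4 `COc1cc(OC)c(-c2coc3cc(OCc4cccc(Cl)c4)ccc3c2=O)cc1OC` differs from compound 2 by 3-chlorobenzyl in place of (3-methoxyphenyl)carbonyl on an oxygen on an aromatic ring. Going by the values given here, the one measured step that bears on this is the exchange of the same ester for the 4-chlorobenzyl ether, an at least 4.1-fold lower number from compound 2 to compound 3 (0.61 log units; beyond the scatter), which took the series from a limit down to a number. The same kind of benzyl ether enters here, so the expected movement in this assay is a drop of similar size, an at least 4.0-fold lower number from compound 2 to compound 4 (0.60 log units; beyond the scatter). Compound 4 is thus estimated at 2500 nM, with a range of 1000 nM to 6500 nM.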

Compound 4, half-maximal inhibitory concentration: 2280 nM
Compound 4: the middle estimate sits 1.1-fold (0.04 log units) above what was measured, within the range that was stated.
By their numbers in this assay, from the lowest: compound 1; then compounds 4 and 3 (each within the scatter of the next). At a limit, above all of these: compound 2.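

In this assay the 3-chlorobenzyl and 4-chlorobenzyl ethers cannot be told apart on this oxygen on an aromatic ring, with a 1.1-fold lower number from compound 3 to compound 4 (0.02 log units; within the scatter). The exchange of the ester for a benzyl-type ether now holds for a second chlorobenzyl group, with an at least 4.3-fold lower number from compound 2 to compound 4 (0.64 log units; beyond the scatter), while the 3-chlorobenzyl ether, like the 4-chlorobenzyl ether, does not reach the prenyl ether, with a 2.1-fold higher number from compound 1 to compound 4 (0.32 log units; beyond the scatter). Compound 2 remains a limit, so the step from it gives a bound and not a size: the limit of > 10000 nM in this assay, at which 1 of the 4 values shown sits.

Open, on these data alone, is how an unsubstituted benzyl ether, or a benzyl ether carrying an amine or a carboxylic acid on its ring, would stand against the chlorobenzyl ethers. Equally open, as far as these compounds go, is whether a longer chain on the same oxygen would hold or pass the level of compound 1.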